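The source may hold more compounds than are shown below. What is called first, only, known or untested is meant among the compounds shown, and "the series" means these compounds.

The measured compounds, each in a functional assay on HL-60 cells (Homo sapiens) for cytotoxicity, read by WST assay, with a stated time of 48 h; on this read-out lower numbers stand for stronger inhibition and higher numbers for weaker inhibition:

Compound 1, `COC[C@H](C(C)C)C(c1ccc(O)c(OC)c1)c1ccc(O)c(OC)c1`, gives 72000 nM.
Compound 2, `COC[C@H](C)[C@@H](C)C(c1ccc(O)c(OC)c1)c1ccc(O)c(OC)c1`, gives 68000 nM.
Compound 3, `COc1cc(C(c2ccc(O)c(OC)c2)[C@@H](C)[C@H](C)CO)ccc1O`, gives only a limit of the assay, > 100000 nM.

Compound 2 holds the lowest of the two numbers, though the gap to its nearest neighbour, a 1.1-fold lower number from compound 1 to compound 2 (0.02 log units; within the scatter), sits within the scatter. The third value is a limit, (the limit of > 100000 nM in this assay, at which 1 of the 3 values shown sits), so the steps of an at least 1.3-fold higher number from compound 1 to compound 3 (0.14 log units; that floor lies within the scatter) and an at least 1.4-fold higher number from compound 2 to compound 3 (0.16 log units; that floor lies within the scatter) give only floors, and those floors also lie within the scatter.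

Compound 4, `COc1cc(C(c2ccc(O)c(OC)c2)[C@@H](CF)C(C)C)ccc1O`, differs from compound 2 as follows: 1-(fluoromethyl)-2-methylpropyl in place of 2-(methoxymethyl)-1-methylpropyl on a saturated chain carbon bound to two aromatic carbons

Within the data shown here, no measured step brings in a 1-(fluoromethyl)-2-methylpropyl group; the measured steps only rearranged the chain or exchanged the 2-(methoxymethyl)-1-methylpropyl for a 2-(hydroxymethyl)-1-methylpropyl, and none of them moved beyond the scatter. The expectation for compound 4 is therefore a step of a 1.0-fold higher number from compound 2 to compound 4 (0.01 log units; within the scatter), meaning no change beyond the scatter. Compound 4 is estimated at 70000 nM, with a range from 30000 nM to 150000 nM.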

Compound 4, half-maximal inhibitory concentration: 39000 nM
Estimate against measurement, compound 4: 1.8-fold (0.25 log units) above; the range from low to high includes it.
By their numbers in this assay, from the lowest: compounds 4, 2 and 1 (each within the scatter of the next). At a limit, above all of these: compound 3.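

In this assay, among these compounds, the 1-(fluoromethyl)-2-methylpropyl group on the saturated chain carbon bound to two aromatic carbons gives the first step at this place that clears the scatter, an at least 2.5-fold lower number from compound 3 to compound 4 (0.40 log units; beyond the scatter), taken against the 2-(hydroxymethyl)-1-methylpropyl group. Against the two methoxymethyl chains it does not clear the scatter, with a 1.7-fold lower number from compound 2 to compound 4 (0.24 log units; within the scatter) and a 1.8-fold lower number from compound 1 to compound 4 (0.27 log units; within the scatter), so the fluoromethyl and methoxymethyl chains cannot be told apart here. The one clear step is only a floor, since compound 3 stands at a limit of the assay: the limit of > 100000 nM in this assay, at which 1 of the 4 values shown sits.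

The compounds shown leave open whether that step follows from the fluorine entering or from the hydroxymethyl leaving. They also leave open how a difluoromethyl group, an aminomethyl group, a carboxylic acid or a longer chain would read at this place.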